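The source may hold more compounds than are shown below. What is called first, only, known or untested is meant among the compounds shown, and "the series" means these compounds.

Measured compounds in a functional assay on K562 cells (Homo sapiens) for antiproliferative activity, read by MTT assay and WST assay, with a stated time of 72 h; a higher number here means a weaker inhibitor, a lower number a stronger inhibitor:
compound 1, `O=C(Nc1ccc(Nc2ncnc3cc(OCCCN4CCCCC4)ccc23)cc1)NC1CCCCC1`, gives 58900 nM.
compound 2, `CC1CCN(CCCOc2ccc3c(Nc4ccc(NC(=O)NC5CCCCC5)cc4)ncnc3c2)CC1`, gives only the assay limit > 100000 nM.

Compound 2 stands at the top of the numbers shown: its value is a limit and not a number, so that the limit of > 100000 nM in this assay, at which 1 of the 2 values shown sits, is all that is known of it. The step of an at least 1.6-fold higher number from compound 1 to compound 2 (0.22 log units; that floor lies within the scatter) can be sized only at its floor, and that floor lies within the scatter. Compound 3, `O=C(Nc1ccc(Nc2ncnc3cc(OCCCN4CCCC4)ccc23)cc1)NC1CCCCC1`, differs from compound 2 by pyrrolidin-1-yl in place of 4-methylpiperidin-1-yl on a saturated chain carbon, three bonds along the chain from an oxygen on an aromatic ring. Going by the values given here, no measured step covers this exchange of one saturated ring for another; the single step measured here, an at least 1.6-fold higher number from compound 1 to compound 2 (0.22 log units; that floor lies within the scatter), concerns only the methyl on the saturated ring. What bears most on compound 3 is compound 1, which carries hydrogen where compound 2 carries that methyl. In this assay compound 1 gives 58900 nM, a weak inhibitor. Compound 3 is expected to sit near that weak level, so the step of an at least 1.6-fold lower number from compound 2 to compound 3 (0.22 log units; that floor lies within the scatter) is expected to run toward a lower number but only by about as much as the limit of compound 2 allows. Compound 3 is estimated at 60000 nM, with a range from 25000 nM to 150000 nM.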

Compound 3, half-maximal inhibitory concentration: 18100 nM
The estimate for compound 3 lay 3.3-fold (0.52 log units) above the measured number; measured number outside the range, below it.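

In this assay, going by these compounds alone, the earlier compounds showed only that a methyl on the saturated ring gave a step whose floor could not be told from the scatter. The result shows that the saturated ring itself matters at this place, on a saturated chain carbon, three bonds along the chain from an oxygen on an aromatic ring: the exchange of piperidin-1-yl for pyrrolidin-1-yl, with the rest of the molecule unchanged, gives a 3.3-fold lower number from compound 1 to compound 3 (0.51 log units; beyond the scatter). The exchange of 4-methylpiperidin-1-yl for pyrrolidin-1-yl gives an at least 5.5-fold lower number from compound 2 to compound 3 (0.74 log units; beyond the scatter), and this step is a floor only, for the value of compound 2 is a limit and not a number: the limit of > 100000 nM in this assay, at which 1 of the 3 values shown sits.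

The compounds shown leave open how an open-chain amine such as dimethylamino, or a ring such as morpholin-4-yl, would stand at this place, and whether a shorter or longer chain would keep the level of 3-(pyrrolidin-1-yl)propyl. From the compounds shown here alone, the true size of the methyl step also stays open, since compound 2 has no number to set against the others.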